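Swapping the guanidine terminus of compound 3 for a thiourea

The source may hold more compounds than are shown below. What is called first, only, known or untested is meant among the compounds shown, and "the series" means these compounds.

Measured compounds:
compound 1, `C/N=C(/NC#N)NCCCn1nc(-c2ccccc2)ccc1=O`, 78.1 mg/kg
compound 2, `CC/N=C(/NC#N)NCCCCn1nc(-c2ccccc2)ccc1=O`, 60.7 mg/kg
compound 3, `N#CNC(=N)NCCCCn1nc(-c2ccccc2)ccc1=O`, 59.3 mg/kg

In a functional assay on the whole organism with Rattus norvegicus as the target (on this read-out lower numbers stand for an effect already at smaller amounts and higher numbers for an effect only at larger amounts of compound), compound 3 gives the lowest of the three numbers, yet both its neighbours stand within the scatter: a 1.0-fold lower number from compound 2 to compound 3 (0.01 log units; within the scatter) and a 1.3-fold lower number from compound 1 to compound 3 (0.12 log units; within the scatter). Compound 4, `CC/N=C(\S)NCCCCn1nc(-c2ccccc2)ccc1=O`, differs from compound 3 by a group of 5 heavy atoms (3 carbon, 1 nitrogen, 1 sulfur; no ring) in place of a group of 5 heavy atoms (2 carbon, 3 nitrogen; no ring), on an amine nitrogen. The step from compound 2 to compound 3, which also touched that amine nitrogen, was flat, and the step from compound 1 to compound 3 on the chain was flat too. Among the measured compounds shown here, no measured pair shows the replacement that brings in sulfur and removes the triple bond, so the bearing steps argue only for a small move. Compound 4 is therefore expected near compound 3, with a 1.0-fold higher number from compound 3 to compound 4 (0.01 log units; within the scatter), at 60 mg/kg (30 mg/kg to 130 mg/kg).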

Compound 4, dose for half-maximal effect: 19.8 mg/kg
Compound 4: middle estimate off by 3.0-fold (0.48 log units), on the high side; measured number below the stated range.
By their numbers in this assay, from the lowest: compound 4; then compounds 3, 2 and 1 (each within the scatter of the next).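

In this assay, among the compounds shown here, a change on the amine nitrogen moves the number beyond the scatter for the first time, with the thiourea terminus giving a 3.0-fold lower number from compound 3 to compound 4 (0.48 log units; beyond the scatter). Compound 4 also stands apart from the other nitrile-bearing compounds, with a 3.1-fold lower number from compound 2 to compound 4 (0.49 log units; beyond the scatter) and a 3.9-fold lower number from compound 1 to compound 4 (0.60 log units; beyond the scatter), the latter step also involving the chain. No measurement here accounts for these steps.

Left open is whether the sulfur or the ethyl group carries the step. A urea with oxygen in place of the sulfur, or a methyl group in place of the ethyl, would separate the two.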